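Bromo on the thiophen-2-yl arm across two cores

The source may hold more compounds than are shown below. What is called first, only, known or untested is meant among the compounds shown, and "the series" means these compounds.

Compound 1 `Clc1cccc(Nc2ncnc3ccc(NCc4cccs4)cc23)c1` and compound 2 `Clc1cccc(Nc2ncnc3ccc(NCc4ccc(Br)s4)cc23)c1` share one core and differ in one place: bromo in place of hydrogen on an aromatic carbon. In a functional assay on HepG2 cells (Homo sapiens) for antiproliferative activity, read by MTT assay, with a stated time of 48 h (on this read-out higher numbers stand for weaker inhibition and lower numbers for stronger inhibition), compound 1 gives 3580 nM and compound 2 gives 3110 nM, so the step of a 1.2-fold lower number from compound 1 to compound 2 (0.06 log units; within the scatter), which says the bromo did not move the number in a way that can be read.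

Compound 3 `O=C(/C=C/c1cccs1)Nc1ccc2ncnc(Nc3cccc(Cl)c3)c2c1` carries a second core; how it differs from the core of compound 1 is (2-(thiophen-2-yl)ethenyl)carbonyl in place of (thiophen-2-yl)methyl on a nitrogen on an aromatic ring. In this assay compound 3 gives 10400 nM, a step of a 2.9-fold higher number from compound 1 to compound 3 (0.46 log units; beyond the scatter) and likewise a 3.3-fold higher number from compound 2 to compound 3 (0.52 log units; beyond the scatter), so this core sits at the weaker end of the three measured compounds.

Compound 4 `O=C(/C=C/c1ccc(Br)s1)Nc1ccc2ncnc(Nc3cccc(Cl)c3)c2c1` is the bromo analogue on the core of compound 3: bromo in place of hydrogen on an aromatic carbon. The place of the change reads the same, word for word, as the place of the change from compound 1 to compound 2, so it is the same change on a different core. Among the compounds with values here, the only measured precedent is the pair of compound 1 and compound 2.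

The step from compound 3 to compound 4 in this assay is expected to be a 1.2-fold lower number from compound 3 to compound 4 (0.06 log units; within the scatter), resting on the step of a 1.2-fold lower number from compound 1 to compound 2 (0.06 log units; within the scatter), which lay within the scatter. Compound 4 is therefore expected to give about 9000 nM, estimated to fall between 4500 nM and 18000 nM. One precedent is thin ground, and the two cores are not shown to respond alike to any other change.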

Compound 4, half-maximal inhibitory concentration: 8850 nM
Compound 4: the middle estimate sits 1.0-fold (0.01 log units) above what was measured, and the stated range covers the measured number.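

In this assay bromo in place of hydrogen on the thiophen-2-yl arm gives a 1.2-fold lower number from compound 3 to compound 4 (0.07 log units; within the scatter) and the change carries from one core to the other with no difference that can be read: the same change on two cores in this assay, a 1.2-fold lower number (0.06 log units; within the scatter) from compound 1 to compound 2 and a 1.2-fold lower number (0.07 log units; within the scatter) from compound 3 to compound 4, 1.0-fold (0.01 log units) apart, within the scatter of two such steps

What carries over here is an absence of a readable effect: on both cores the thiophen-2-yl to 5-bromothiophen-2-yl change leaves the number within the scatter, so the agreement between the two steps is agreement between two small steps, not a shared shift of measurable size. It does not show that the two cores respond alike to a change that moves the number, since this change moves it on neither core. Within the data shown here, the evidence also covers only two pairs, one substituent, one place on the ring and one read-out, so it supports no general rule of transfer for the series.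

Left open is whether a methoxy group, an amine or a carboxylic acid at the place of the bromo would move the number on either core and, if so, whether such a step would match between the two cores. Also open, going by these compounds, is whether the bromo step stays this small in any read-out other than this assay or on any core beyond these two.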